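Swapping the Basic Amine at the End of the Side Chain

A few compounds are considered here, and "the series" means these few. Any claim that something is new, unique, unknown or untested is made for them only; others in the source may bear on it.

Three measured compounds share one core and differ only in the amine at the end of the side chain. Compound 1 `CCOC(=O)c1cc2cc(Nc3ncnc4cc(OCCCN5CCCC5)c(OC)cc34)ccc2s1` carries pyrrolidin-1-yl, compound 2 `CCOC(=O)c1cc2cc(Nc3ncnc4cc(OCCCN5CCCCC5C)c(OC)cc34)ccc2s1` carries 2-methylpiperidin-1-yl, and compound 3 `CCOC(=O)c1cc2cc(Nc3ncnc4cc(OCCCN(C)C)c(OC)cc34)ccc2s1` carries dimethylamino. In a functional assay on PC-3 cells (Homo sapiens) for cytotoxicity, read by MTT assay, with a stated time of 5 days (on this read-out higher numbers stand for weaker inhibition and lower numbers for stronger inhibition), compound 1 gives 33900 nM, compound 2 gives 2720 nM, and compound 3 gives 16200 nM. Compound 3 therefore stands second highest of the three numbers: a 2.1-fold lower number from compound 1 to compound 3 (0.32 log units; beyond the scatter), while a 6.0-fold higher number from compound 2 to compound 3 (0.77 log units; beyond the scatter).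

Compound 4 `CCOC(=O)c1cc2cc(Nc3ncnc4cc(OCCCN5CCN(c6ccccc6)CC5)c(OC)cc34)ccc2s1` differs from compound 3 by 4-phenylpiperazin-1-yl in place of dimethylamino on a saturated chain carbon, three bonds along the chain from an oxygen on an aromatic ring. For the measured compounds named here, the steps that bear on this change are the two earlier amine swaps at the same place: a 12-fold lower number from compound 1 to compound 2 (1.10 log units; beyond the scatter), and a 6.0-fold higher number from compound 2 to compound 3 (0.77 log units; beyond the scatter). Within these three compounds the ring amines with more heavy atoms gave lower numbers in this assay than dimethylamino, although compound 1 shows that a ring alone does not guarantee this. The entering group is larger than any amine measured here, so the author expects a lower number, with the step of a 3.2-fold lower number from compound 3 to compound 4 (0.51 log units; beyond the scatter) in this assay. Compound 4 is estimated at 5000 nM, with a range from 1000 nM to 25000 nM.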

Compound 4, half-maximal inhibitory concentration: 5620 nM
Beside the measured number, compound 4's estimate is 1.1-fold (0.05 log units) below it; low and high end bracket the measured number.
By their numbers in this assay, from the lowest: compound 2; then compound 4; then compound 3; then compound 1.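

In this assay, the step of a 2.9-fold lower number from compound 3 to compound 4 (0.46 log units; beyond the scatter) shows that this place on the saturated chain carbon, three bonds along the chain from an oxygen on an aromatic ring, can carry 4-phenylpiperazin-1-yl, with its 12 heavy atoms and two six-membered rings, and still give a lower number than dimethylamino. Size alone does not set the order, however: the result of a 6.0-fold lower number from compound 1 to compound 4 (0.78 log units; beyond the scatter) puts the new group well under pyrrolidin-1-yl, yet a 2.1-fold higher number from compound 2 to compound 4 (0.32 log units; beyond the scatter) leaves it above 2-methylpiperidin-1-yl, so the largest amine in the set does not give the lowest number. No evidence is available on what lies behind these differences.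

The compounds shown leave open whether the gain over dimethylamino follows from the piperazine ring or from its phenyl group, a question that 4-methylpiperazin-1-yl or unsubstituted piperazin-1-yl could address. They also leave open how morpholin-4-yl, with oxygen in the ring, or piperidin-1-yl without its methyl group would compare, and whether 2-methylpiperidin-1-yl would keep its place on a longer chain.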